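A Third Aryl Amide on the Shared Core

This account rests on a few compounds, and the source may have more. Where it says the series, first, only, none or still open, it means among the compounds named here.

Among the measured compounds shown here, compound 2 `O=C(Nc1cccc(-c2oc3cc(-c4ccc(F)cc4)ccc3c(=O)c2O)c1)c1cccc(F)c1` gives 15400 nM in a functional assay on A549 cells (Homo sapiens) for antiproliferative activity, read by CCK-8 assay, with a stated time of 72 h (a lower number here means a stronger inhibitor, a higher number a weaker inhibitor), the lower of the two numbers measured so far; compound 1 `Cc1ccccc1C(=O)Nc1cccc(-c2oc3cc(-c4ccc(F)cc4)ccc3c(=O)c2O)c1` gives 17600 nM, and the two sit within the scatter of each other. These compounds differ only in the aryl group on a carbonyl carbon. Compound 3 `O=C(Nc1cccc(-c2oc3cc(-c4ccc(F)cc4)ccc3c(=O)c2O)c1)c1cnc(Cl)nc1Cl` varies that same group once more: 2,4-dichloropyrimidin-5-yl in place of 3-fluorophenyl on a carbonyl carbon. Because a 1.1-fold lower number from compound 1 to compound 2 (0.06 log units; within the scatter) stayed within the scatter for an earlier swap on the carbonyl carbon, no step beyond the scatter is expected here either. Compound 3 is therefore estimated at 15000 nM, ranging from 5000 nM to 45000 nM, an expected step of a 1.0-fold lower number from compound 2 to compound 3 (0.01 log units; within the scatter).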

Compound 3, half-maximal inhibitory concentration: > 100000 nM
Compound 3: a limit, no number; the forecaster's own chance of this, stated with the estimate: 5%; at least 6.6-fold (0.82 log units) between middle value and limit.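

Up to this point the position looked forgiving, with a 1.1-fold lower number from compound 1 to compound 2 (0.06 log units; within the scatter). Putting 2,4-dichloropyrimidin-5-yl on the carbonyl carbon gives an at least 6.4-fold higher number from compound 2 to compound 3 (0.81 log units; beyond the scatter) and an at least 5.6-fold higher number from compound 1 to compound 3 (0.75 log units; beyond the scatter), so the aryl group here can matter for activity. For compound 3 the reading is a limit of the assay, not a number: the limit of > 100000 nM in this assay, at which 1 of the 3 values shown sits.

The change brings in ring nitrogen and chlorine together, so the compounds shown cannot tell which of the two goes with the loss. From the compounds shown here alone, a pyrimidin-5-yl without chlorine, or a phenyl carrying chlorine, would separate them, and how either reads remains open.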